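The compounds below may be only part of what the source reports. "The series", "measured", "known", "first", "only" and "open" are said of these compounds alone.

Measured compounds:
- compound 1 `COc1cc(-c2cc(/C=C/C(=O)c3ccc(N)cc3)[nH]n2)cc(OC)c1OC`: 66%
- compound 2 `COc1ccc(-c2cc(/C=C/C(=O)c3ccc(N)cc3)[nH]n2)cc1OC`: 81%

Among the measured compounds shown here, in a functional assay on MCF7 cells (Homo sapiens) for cytotoxicity, read by sulforhodamine B assay, with a stated time of 48 h, tested at 1 uM (on this read-out lower numbers stand for a stronger effect and higher numbers for a weaker effect at the one concentration tested), compound 1 gives 66%, the lowest of the two numbers; the one step from it, a number 15 percentage points higher from compound 1 to compound 2 (beyond the scatter), is hydrogen in place of methoxy on an aromatic carbon. Compound 3 `COc1ccc(C(=O)/C=C/c2cc(-c3cc(OC)c(OC)c(OC)c3)n[nH]2)cc1` differs from compound 1 by methoxy in place of amino on an aromatic carbon, on the 4-aminophenyl side. For the measured compounds named here, no measured step touches that ring, so the step from compound 1 bears only loosely on it. The step from compound 1 to compound 3 in this assay is therefore expected to stay near or within the scatter, a number 6 percentage points higher from compound 1 to compound 3 (within the scatter). For compound 3 the estimate is 72%, range 52% to 92%.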

Compound 3, a percentage reported as activity, at one concentration (the size of the read-out at that concentration, not a potency): 57%
For compound 3 the middle estimate is 15 percentage points above the measured one, within the range that was stated.
By their numbers in this assay, from the lowest: compounds 3 and 1 (each within the scatter of the next); then compound 2.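

In this assay, among the compounds shown here, the swap of 4-aminophenyl for 4-methoxyphenyl gives a number 9 percentage points lower from compound 1 to compound 3 (within the scatter) and is the first reading on this side of the molecule. For the compounds shown here, at this one concentration, the amino group on this ring is therefore not required for the effect, since methoxy serves within the scatter in the one pair read. No measured evidence explains this result. Open, on these data alone, is whether a hydroxy group, a dimethylamino group or a carboxylic acid at the same place would behave alike. Also open, as far as these compounds go, is whether the swap would read the same on the core of compound 2.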